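Swapping the aryl group of compound 2 for 4-fluorophenyl

This account rests on a few compounds, and the source may have more. Where it says the series, first, only, none or still open, it means among the compounds named here.

Compound 1 `O=C(/C(=C\c1csc([N+](=O)[O-])c1)S(=O)(=O)c1ccc(Br)cc1)c1ccc(Br)cc1`: 1000 nM
Compound 2 `O=C(/C(=C\c1ccc(Cl)c([N+](=O)[O-])c1)S(=O)(=O)c1ccc(Br)cc1)c1ccc(Br)cc1`: 10000 nM
Compound 3 `O=C(/C(=C\c1ccc(Cl)c([N+](=O)[O-])c1)Sc1ccc(Br)cc1)c1ccc(Br)cc1`: 10000 nM

In a functional assay on DU-145 cells (Homo sapiens) for inhibition, read by trypan blue exclusion, with a stated time of 96 h (on this read-out higher numbers stand for weaker inhibition of growth and lower numbers for stronger inhibition of growth), compound 2 gives 10000 nM, level with compound 3, and the two share the highest number of the three. Compound 4 `O=C(/C(=C\c1ccc(F)cc1)S(=O)(=O)c1ccc(Br)cc1)c1ccc(Br)cc1` has not yet been measured. It differs from compound 2 as follows: 4-fluorophenyl in place of 4-chloro-3-nitrophenyl on a double-bonded chain carbon bound to a double-bonded chain carbon. Among the measured compounds shown here, the closest precedent is a change at this same place, a 10-fold higher number from compound 1 to compound 2 (1.00 log units; beyond the scatter), which was beyond the scatter. The other step, no change at the digits printed from compound 2 to compound 3 (within the scatter), changes a different part of the molecule and says little here. For the measured compounds named here, no measured compound carries 4-fluorophenyl, so the direction is uncertain, and only a small drop in the number is expected. The estimated change is a 1.7-fold lower number from compound 2 to compound 4 (0.22 log units; within the scatter). For compound 4 the expected value is 6000 nM, with an estimated range of 1500 nM to 20000 nM.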

Compound 4, concentration for 50% growth inhibition: 4000 nM
For compound 4 the middle estimate is 1.5-fold (0.18 log units) above the measured one; measured number inside the range.
By their numbers in this assay, from the lowest: compound 1; then compound 4; then compounds 2 and 3 (each within the scatter of the next).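

The step of a 2.5-fold lower number from compound 2 to compound 4 (0.40 log units; beyond the scatter) shows that a number below that of compound 2 does not need a nitro group at this position. The step of a 4.0-fold higher number from compound 1 to compound 4 (0.60 log units; beyond the scatter) shows that 5-nitrothiophen-3-yl still gives the lowest number of these three groups, so compound 2 goes against any simple link between a nitro group and a lower number. No measurement shown explains this order.
On these data alone, the chlorine and nitro group leave together, so the share of each stays open. As far as these compounds go, how an amine or a carboxylic acid at this place would behave also remains open.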